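A few compounds are considered here, and "the series" means these few. Any claim that something is new, unique, unknown or untested is made for them only; others in the source may bear on it.

Of the compounds shown here, three built on one shared core have been measured in a functional assay on CHO cells for agonist activity at Free fatty acid receptor 1 (Homo sapiens), read by FLIPR and calcium flux, tested at 100 nM; on this read-out higher numbers stand for a stronger effect at the one concentration tested and lower numbers for a weaker effect. Compound 1 `Cc1nc(-c2ccsc2)sc1COc1ccc2c(c1)OCC2CC(=O)O` carries a thiophen-3-yl group on the core and gives 56.5%. Compound 2 `Cc1nc(-c2ccc(Cl)s2)sc1COc1ccc2c(c1)OCC2CC(=O)O` carries a 5-chlorothiophen-2-yl group and gives 8.34%, so that a number 48.2 percentage points lower from compound 1 to compound 2 (beyond the scatter). Compound 3 `Cc1cccc(-c2nc(C)c(COc3ccc4c(c3)OCC4CC(=O)O)s2)c1` carries a 3-methylphenyl group and gives 47.2%, which places it second highest of the three numbers: a number 9.3 percentage points lower from compound 1 to compound 3 (within the scatter), whereas a number 38.9 percentage points higher from compound 2 to compound 3 (beyond the scatter).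

Compound 4 `Cc1nc(-c2ccc(Cl)cc2)sc1COc1ccc2c(c1)OCC2CC(=O)O` has not yet been measured. Within the data shown here, its single change from compound 3 is this: 4-chlorophenyl in place of 3-methylphenyl on an aromatic carbon. The change sits on an aromatic carbon of the five-membered aromatic ring with 1 nitrogen and 1 sulfur. Among the measured compounds shown here, two measured steps bear on it. The step from compound 1 to compound 3 shows that exchanging a thiophen-3-yl for a 3-methylphenyl stayed within the scatter, while the steps from compound 1 to compound 2 and from compound 2 to compound 3 show that a chlorine-bearing ring went with a large fall. For the measured compounds named here, a chlorine now enters on a six-membered ring, and no measured pair shows that exact exchange, so the expectation is uncertain but leans downward. Compound 4 is expected to give 30%, within 5% to 60%, which would mean a number 17.2 percentage points lower from compound 3 to compound 4 (beyond the scatter).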

Compound 4, a percentage reported as activity, at one concentration (the size of the read-out at that concentration, not a potency): 53.4%
Compound 4: the middle estimate sits 23.4 percentage points below what was measured, within the range that was stated.
By their numbers in this assay, from the lowest: compound 2; then compounds 3, 4 and 1 (each within the scatter of the next).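

In this assay there is a number a number 6.2 percentage points higher from compound 3 to compound 4 (within the scatter), so on this carbon of the five-membered ring a chlorine on a six-membered ring reads no differently from the methyl of the 3-methylphenyl group. The earlier link between a chlorine-bearing ring and a large fall therefore does not hold as a general pattern: there is also a number a number 3.1 percentage points lower from compound 1 to compound 4 (within the scatter), within the scatter, while there is a number a number 45.1 percentage points higher from compound 2 to compound 4 (beyond the scatter), a large gap that leaves compound 2 alone at the low end among the groups shown. No measured evidence on why these groups read as they do is available for this result.

The compounds shown leave open whether the low number of compound 2 goes with its chlorine or with the thiophen-2-yl ring that carries it, a question that a plain thiophen-2-yl group would address. They also leave open how an amine or a longer chain would read on this same carbon of the ring.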